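Chloro for hydrogen on the thiazole-bound phenyl of compound 2

A few compounds are considered here, and "the series" means these few. Any claim that something is new, unique, unknown or untested is made for them only; others in the source may bear on it.

Of the compounds shown here, two have been measured so far. Compound 1 `COc1ccc(-c2nc(C)c(C(=O)CSc3nc(N)c(C#N)c(-c4ccc(Cl)cc4)n3)s2)cc1` and compound 2 `Cc1nc(-c2ccccc2)sc1C(=O)CSc1nc(N)c(C#N)c(-c2ccc(Cl)cc2)n1` share the same core and differ only at one aromatic carbon, where compound 1 carries a methoxy group and compound 2 a hydrogen. In a functional assay on U-87MG ATCC cells for antiproliferative activity against U-87 MG (Homo sapiens), read by MTT assay, with a stated time of 48 h, tested at 10 uM (a lower number here means a stronger effect, a higher number a weaker effect of the compound at the concentration tested), compound 1 gives 44%, and compound 2 gives 58.8%, so that the change a number 14.8 percentage points higher from compound 1 to compound 2 (beyond the scatter). Compound 2 thus stands with the highest of the two numbers measured, its nearest neighbour being compound 1.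

Compound 3 `Cc1nc(-c2ccc(Cl)cc2)sc1C(=O)CSc1nc(N)c(C#N)c(-c2ccc(Cl)cc2)n1` is not yet measured. Compared with compound 2 the change is chloro in place of hydrogen on an aromatic carbon, on an aromatic carbon of a six-membered aromatic ring of carbon only, para to a large group. Among the measured compounds shown here, no measured step covers a chloro group; the only step known, from hydrogen to methoxy at the same place, was of modest size. It is therefore expected that compound 3 shows a step of a number 8.8 percentage points lower from compound 2 to compound 3 (within the scatter) that could well stay within the scatter, with a number estimated at 50% and a range from 30% to 72%.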

Compound 3, a percentage reported as activity, at one concentration (the size of the read-out at that concentration, not a potency): 37.3%
Compound 3: the middle estimate sits 12.7 percentage points above what was measured; the range from low to high includes it.
By their numbers in this assay, from the lowest: compounds 3 and 1 (each within the scatter of the next); then compound 2.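

In this assay, the chloro group at this place gives a number 21.5 percentage points lower from compound 2 to compound 3 (beyond the scatter), a step beyond the scatter, so the phenyl to 4-chlorophenyl change strengthens the effect at the concentration tested. Among the compounds shown here, until now, methoxy was the only group that could be compared with hydrogen here; chloro now shows that a second, quite different group also gives a lower number than hydrogen, leaving compound 2 as the weakest of the three. The exchange of methoxy for chloro gives a number 6.7 percentage points lower from compound 1 to compound 3 (within the scatter), which lies within the scatter, so the assay does not separate these two groups, and no evidence is available to explain why either one differs from hydrogen.

The compounds shown leave open whether the same lower number would appear with a bromo group, a methyl group, an amine or a carboxylic acid at this place, so two substituents cannot yet be called a trend across groups in general. They also leave open how the three compounds compare in the size of their effect at any other concentration, since each has a read-out at one concentration only.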